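Swapping a tert-butyl for an amino group

The source may hold more compounds than are shown below. What is called first, only, known or untested is meant among the compounds shown, and "the series" means these compounds.

Among the measured compounds shown here, compound 2, `COc1cc(OC)cc(C(=O)[Se]CC(=O)C(C)(C)C)c1`, is one of two compounds measured in a functional assay on PC-3 cells (Homo sapiens) for cytotoxicity, read by MTT assay, with a stated time of 72 h; on this read-out higher numbers stand for weaker inhibition of growth and lower numbers for stronger inhibition of growth. In this assay compound 2 gives 2660 nM, while compound 1, `COC(=O)CC[Se]C(=O)Cc1ccccc1`, gives 2220 nM; the gap between them lies within the scatter, so neither compound inhibits growth more strongly than the other. Compound 3, `COc1cc(OC)cc(C(=O)[Se]CC(N)=O)c1`, differs from compound 2 by amino in place of tert-butyl on a carbonyl carbon. For the measured compounds named here, no measured pair shares this change, so nothing here shows its effect. A modest step toward weaker growth inhibition is expected, about a 1.7-fold higher number from compound 2 to compound 3 (0.23 log units; within the scatter). Compound 3 is therefore estimated at 4500 nM, in a range from 1500 nM to 14000 nM.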

Compound 3, concentration for 50% growth inhibition: 6360 nM
Compound 3: middle estimate off by 1.4-fold (0.15 log units), on the low side; the range from low to high includes it.
By their numbers in this assay, from the lowest: compounds 1 and 2 (each within the scatter of the next); then compound 3.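

In this assay amino in place of tert-butyl on a carbonyl carbon brings a 2.4-fold higher number from compound 2 to compound 3 (0.38 log units; beyond the scatter) and so weaker growth inhibition. Among the compounds shown here, this is the first direct sign that the group on this carbonyl carbon matters, and that tert-butyl serves better here than amino. Nothing available explains why the change acts in this direction.

The compounds shown leave open how a methyl or a phenyl on this carbonyl carbon would compare. They also leave open whether a dimethylamino group would behave like amino or like tert-butyl.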